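Terminal ring change with the hydroxy kept

The compounds below may be only part of what the source reports. "The series", "measured", "known", "first", "only" and "open" are said of these compounds alone.

Among the compounds with values here, in a functional assay on A549 cells (Homo sapiens) for inhibition, read by sulforhodamine B assay (on this read-out higher numbers stand for weaker inhibition of growth and lower numbers for stronger inhibition of growth), compound 3 `Oc1cccc2[nH]c(-c3ccc(-c4ccc(-c5ccc(OC(F)(F)F)cc5)cc4)cc3)nc12` gives 190 nM, the lowest number so far, against compound 2 `COc1ccc(-c2ccc(-c3ccc(-c4nc5ccccc5[nH]4)cc3)cc2)cc1OC` at 7600 nM and compound 1 `FC(F)(F)Oc1ccc(-c2ccc(-c3ccc(-c4nc5ccccc5[nH]4)cc3)cc2)cc1` at 38000 nM. Compound 4 `Oc1cccc2[nH]c(-c3ccc(-c4ccc(-c5cccc(Cl)c5)cc4)cc3)nc12` keeps the hydroxy and carries 3-chlorophenyl in place of 4-(trifluoromethoxy)phenyl (3-chlorophenyl in place of 4-(trifluoromethoxy)phenyl on an aromatic carbon). Within the data shown here, the one measured step, a 200-fold lower number from compound 1 to compound 3 (2.30 log units; beyond the scatter), concerns the hydroxy and not this change, so it sets no size here. The only hint on the terminal ring is the gap between the values of compound 1 and compound 2, both without the hydroxy. A moderate rise is therefore expected, with wide uncertainty: a 2.1-fold higher number from compound 3 to compound 4 (0.32 log units; beyond the scatter). For compound 4 the estimated value is 400 nM, with an expected range of 100 nM to 2000 nM.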

Compound 4, concentration for 50% growth inhibition: 2400 nM
Compound 4: the middle estimate sits 6.0-fold (0.78 log units) below what was measured, and the stated range ends below it.
By their numbers in this assay, from the lowest: compound 3; then compound 4; then compound 2; then compound 1.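

With the hydroxy kept, the terminal ring is not a neutral position in this assay: 3-chlorophenyl in place of 4-(trifluoromethoxy)phenyl gives a 13-fold higher number from compound 3 to compound 4 (1.10 log units; beyond the scatter). Within the data shown here, this is the first measured step at this position, and its size shows that the hydroxy alone does not fix the level of growth inhibition. No evidence is at hand on the reason for this step.

As far as these compounds go, the identity of the substituent and its ring position change together here, so their shares in the step remain open. Also open, from the compounds shown here alone, is how a terminal ring carrying an amine or a carboxylic acid would read with the hydroxy kept.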